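This account rests on a few compounds, and the source may have more. Where it says the series, first, only, none or still open, it means among the compounds named here.

Compound 1 `O=C(c1cccc(Cl)c1)N1CCC(NS(=O)(=O)c2cc(S(=O)(=O)c3ccccc3)ccc2C(F)(F)F)CC1` gives 300 nM in an assay on isolated protein for displacement of a labelled ligand from secreted frizzled-related protein 1 (Homo sapiens), read by fluorescence polarization, with a stated time of 30 min; on this read-out higher numbers stand for weaker inhibition and lower numbers for stronger inhibition.
Compound 2 `O=C(c1ccc(Cl)nc1)N1CCC(NS(=O)(=O)c2cc(S(=O)(=O)c3ccccc3)ccc2C(F)(F)F)CC1` gives 110 nM in this assay.
Compound 3 `O=C(O)c1ccc(N2CCC(NS(=O)(=O)c3cc(S(=O)(=O)c4ccccc4)ccc3C(F)(F)F)CC2)cc1` gives 120 nM in this assay.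

Compound 3 stands second highest of the three numbers in this assay. Its nearest neighbour is compound 2, with a 1.1-fold higher number from compound 2 to compound 3 (0.04 log units; within the scatter); the furthest is compound 1, with a 2.5-fold lower number from compound 1 to compound 3 (0.40 log units; beyond the scatter).

Compound 4 `O=C(CC1CCNCC1)N1CCC(NS(=O)(=O)c2cc(S(=O)(=O)c3ccccc3)ccc2C(F)(F)F)CC1` awaits measurement. It differs from compound 3 in one place: ((piperidin-4-yl)methyl)carbonyl in place of 4-carboxyphenyl on an amine nitrogen in a ring. Among the compounds with values here, two measured steps touch the same ring nitrogen, a 2.5-fold lower number from compound 1 to compound 3 (0.40 log units; beyond the scatter) and a 1.1-fold higher number from compound 2 to compound 3 (0.04 log units; within the scatter); the third, a 2.7-fold lower number from compound 1 to compound 2 (0.44 log units; beyond the scatter), alters the aryl group on the carbonyl. Every change at this end of the core has been modest or within the scatter. Within the data shown here, none of the measured compounds carries a non-aromatic ring at this position, so the direction of the step is not fixed by the data.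

For compound 4 the expected step is a 1.7-fold higher number from compound 3 to compound 4 (0.22 log units; within the scatter) in this assay, no further than the scatter allows. The estimate for compound 4 is 200 nM, expected to fall between 70 nM and 600 nM.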

Compound 4, half-maximal inhibitory concentration: 100 nM
Compound 4: the middle estimate sits 2.0-fold (0.30 log units) above what was measured; the range from low to high includes it.
By their numbers in this assay, from the lowest: compounds 4, 2 and 3 (each within the scatter of the next); then compound 1.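

Compound 4 alone among the four carries a non-aromatic ring in the group on this amine nitrogen. The steps of a 1.2-fold lower number from compound 3 to compound 4 (0.08 log units; within the scatter) and a 1.1-fold lower number from compound 2 to compound 4 (0.04 log units; within the scatter) in this assay show that ((piperidin-4-yl)methyl)carbonyl, with no aromatic ring in the group, reads level with the aromatic groups of those two compounds, while only a 3.0-fold lower number from compound 1 to compound 4 (0.48 log units; beyond the scatter) lies beyond the scatter, which leaves compound 1 with its 3-chlorophenyl group apart from the other three. No measurement given here bears on why such different groups read alike.

From the compounds shown here alone, whether a cyclohexyl group in place of the piperidin-4-yl ring, or a longer chain on the carbonyl carbon, would keep the number at this level stays open. So does whether an open-chain amine would serve as well as the ring.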